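Aryl variation on a trimethoxyphenyl-bearing bicyclic core

The source may hold more compounds than are shown below. What is called first, only, known or untested is meant among the compounds shown, and "the series" means these compounds.

Compounds with their results in a functional assay on HCT-116 cells (Homo sapiens) for inhibition, read by CCK-8 assay, with a stated time of 48 h; a higher number here means a weaker inhibitor, a lower number a stronger inhibitor:
compound 1 `COc1cc(-c2ccnc3cc(-c4ccc(N(C)C)cc4)nn23)cc(OC)c1OC`: 2050 nM
compound 2 `COc1cc(-c2ccnc3cc(-c4ccc5c(ccn5C)c4)nn23)cc(OC)c1OC`: 39 nM
compound 3 `COc1cc(-c2ccnc3cc(-c4ccc(F)cc4)nn23)cc(OC)c1OC`: 5030 nM

Compound 3 has the highest number of the three; compound 1 is nearest with a 2.5-fold higher number from compound 1 to compound 3 (0.39 log units; beyond the scatter), and compound 2 is furthest with a 130-fold higher number from compound 2 to compound 3 (2.11 log units; beyond the scatter). Compound 4 `COc1cc(-c2ccnc3cc(-c4cccc(C)c4)nn23)cc(OC)c1OC` arises from compound 3 through (3-methylphenyl in place of 4-fluorophenyl on an aromatic carbon). Going by the values given here, no measured step swaps one plain phenyl substituent for another; the modest step of a 2.5-fold higher number from compound 1 to compound 3 (0.39 log units; beyond the scatter) is the closest guide, whereas the large step of a 130-fold higher number from compound 2 to compound 3 (2.11 log units; beyond the scatter) concerns a different ring type. Compound 4 is therefore expected to stay near compound 3, a step of a 1.4-fold lower number from compound 3 to compound 4 (0.16 log units; within the scatter), not clearly beyond the scatter. Compound 4 is estimated at 3500 nM, within 1200 nM to 10000 nM.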

Compound 4, half-maximal inhibitory concentration: 6150 nM
Compound 4: the middle estimate sits 1.8-fold (0.24 log units) below what was measured; the measured number falls inside the stated range.
By their numbers in this assay, from the lowest: compound 2; then compound 1; then compounds 3 and 4 (each within the scatter of the next).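

Replacing 4-fluorophenyl with 3-methylphenyl on this aromatic carbon of the five-membered ring changes little in this assay, a 1.2-fold higher number from compound 3 to compound 4 (0.09 log units; within the scatter), so these two plain phenyl substituents cannot be told apart here. Compound 4 lies far from the indole compound, a 160-fold higher number from compound 2 to compound 4 (2.20 log units; beyond the scatter), and more modestly from the dimethylamino compound, a 3.0-fold higher number from compound 1 to compound 4 (0.48 log units; beyond the scatter), so the wide gap to compound 2 now holds against two plain phenyl substituents. No available measurement explains these differences. The compounds shown leave open whether a naphthyl group or an unmethylated 1H-indol-5-yl would match compound 2.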